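Furan-to-thiophene swap on a nucleoside-like core

This account rests on a few compounds, and the source may have more. Where it says the series, first, only, none or still open, it means among the compounds named here.

Three compounds that share a sugar attached to a two-ring core have been tested in a functional assay on HCT-116 cells (Homo sapiens), read by MTT assay, with a stated time of 72 h; on this read-out lower numbers stand for stronger inhibition and higher numbers for weaker inhibition. Compound 1 `O=c1[nH]cnc2c1c(-c1ccoc1)cn2[C@@H]1O[C@H](CO)[C@@H](O)[C@H]1O` gives 10300 nM there. Compound 2 `COc1ncnc2c1c(-c1ccoc1)cn2[C@@H]1O[C@H](CO)[C@@H](O)[C@H]1O` gives 110 nM in this assay, a lower number than compound 1 and the lowest of the two numbers in hand; how the two cores differ is not broken down here. Compound 3 `O=c1[nH]cnc2c1c(-c1cccs1)cn2[C@@H]1O[C@H](CO)[C@@H](O)[C@H]1O` carries thiophen-2-yl in place of furan-3-yl on an aromatic carbon, as set out in thiophen-2-yl in place of furan-3-yl on an aromatic carbon. The value of compound 3 in this assay, > 20000 nM, is a limit of the assay and not a number, namely (the limit of > 20000 nM in this assay, at which 1 of the 3 values shown sits). The step this change made, an at least 1.9-fold higher number from compound 1 to compound 3 (0.28 log units; that floor lies within the scatter), therefore gives only a floor for how much weaker the inhibition became.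

Compound 4 `COc1ncnc2c1c(-c1cccs1)cn2[C@@H]1O[C@H](CO)[C@@H](O)[C@H]1O` has not been measured in this assay. Among the measured compounds shown here, it differs from compound 2 by thiophen-2-yl in place of furan-3-yl on an aromatic carbon, the same change as the one from compound 1 to compound 3, made at the same place. From compound 2 to compound 4 the step is expected to be a 3.2-fold higher number from compound 2 to compound 4 (0.50 log units; beyond the scatter), a weakening, because an at least 1.9-fold higher number from compound 1 to compound 3 (0.28 log units; that floor lies within the scatter) points that way while giving only a floor for its size. Compound 4 is thus estimated at 350 nM in this assay, expected to fall between 120 nM and 1500 nM.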

Compound 4, half-maximal inhibitory concentration: 80 nM
For compound 4 the middle estimate is 4.4-fold (0.64 log units) above the measured one; the measured number lies below the stated range.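

In this assay, putting thiophen-2-yl in place of furan-3-yl on the core of compound 2 gives a 1.4-fold lower number from compound 2 to compound 4 (0.14 log units; within the scatter), so on this core the measured numbers do not tell the two rings apart. Set beside the same change on the core of compound 1, this result does not show that the change behaves differently on the two cores, and it does not show that it behaves alike either: the same change on two cores in this assay, an at least 1.9-fold higher number (0.28 log units; that floor lies within the scatter) from compound 1 to compound 3 and a 1.4-fold lower number (0.14 log units; within the scatter) from compound 2 to compound 4; the limit leaves it open whether they differ. Going by these compounds, the reading for compound 3 is a limit of the assay and not a number, so the full size of the step on the core of compound 1 remains unknown, and only a floor can be carried into the comparison: the limit of > 20000 nM in this assay, at which 1 of the 4 values shown sits.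

The compounds shown cover only furan-3-yl and thiophen-2-yl at this aromatic carbon, so it remains open how a phenyl ring, an amine or a longer alkyl chain placed there would read in this assay. With only two cores shown, it is also open whether the same swap would give a readable step on a core that carries a carboxylic acid or an amine.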